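The compounds below may be only part of what the source reports. "The series", "measured", "known", "first", "only" and "open" are said of these compounds alone.

Compound 1: `CN(C)c1ccc(C(=O)Nc2cccc(NC(=O)COc3ccc4c(c3)OCCC4=O)c2)cc1`, giving 144 nM in an assay on isolated protein for inhibition of Rho-associated protein kinase 1 (Homo sapiens), read by scintillation counting, radiometric assay and 33P incorporation, with a stated time of 40 min, in the presence of a further agent that is not named here; on this read-out higher numbers stand for weaker inhibition and lower numbers for stronger inhibition.
Compound 2: `Cc1c(OCC(=O)Nc2cccc(NC(=O)c3ccc(N(C)C)cc3)c2)ccc2c(=O)ccoc12`; in this assay compound 2 reaches only the limit > 10000 nM, which is a boundary of the measurement and not a number.
Compound 3: `CCCC(=O)Nc1cccc(NC(=O)COc2ccc3c(=O)ccoc3c2)c1`, giving 1430 nM in this assay.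

Among the numbers actually measured, compound 3 stands highest: its nearest neighbour is compound 1, whose value is lower by a margin beyond the usual scatter. Compound 2 sits at the boundary described by the limit of > 10000 nM in this assay, at which 1 of the 3 values shown sits, so its standing relative to compound 3 cannot be ordered.

The step under consideration leads from compound 3 to compound 4, `COC(=O)c1ccc(C(=O)Nc2cccc(NC(=O)COc3ccc4c(=O)ccoc4c3)c2)cc1`, which has not yet been measured in this assay. The change is 4-(methoxycarbonyl)phenyl in place of propyl on a carbonyl carbon. Within the data shown here, no measured pair in this set differs in exactly this way, so the size of the step is open. Compound 1, which also carries an aromatic amide, gives 144 nM, while compound 3 with its propyl gives 1430 nM; these two structures differ in more than one place, so only their values can be compared. On that basis compound 4 is expected to move toward stronger inhibition, with an estimated step of a 2.9-fold lower number from compound 3 to compound 4 (0.46 log units; beyond the scatter). For compound 4 the estimate in this assay is 500 nM, in a range from 120 nM to 2500 nM.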

Compound 4, half-maximal inhibitory concentration: 72 nM
For compound 4 the middle estimate is 6.9-fold (0.84 log units) above the measured one, and the stated range ends above it.
By their numbers in this assay, from the lowest: compounds 4 and 1 (each within the scatter of the next); then compound 3. At a limit, above all of these: compound 2.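

In this assay, the carbonyl carbon whose other neighbour is the amide-type nitrogen proves to be a place where the group carried matters a great deal: putting 4-(methoxycarbonyl)phenyl in place of propyl gives a 20-fold lower number from compound 3 to compound 4 (1.30 log units; beyond the scatter) and counts as a large step. Among these compounds, the earlier compounds offered no pair differing in only one place, so this is the first direct reading of any single change in the set, and it shows that on the core shared by these two compounds the larger aromatic group goes with clearly stronger inhibition than the short chain. Nothing among the data shown accounts for the size of this step.

From the compounds shown here alone, a single step cannot separate what the six-membered aromatic ring contributes from what the methoxycarbonyl group on it contributes, so the share of each remains unknown. An unsubstituted phenyl, a carboxylic acid in place of the methyl ester, or a dimethylamino group on the same ring would each address that question, and a chain longer than propyl would show whether the aromatic ring is needed at all.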